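The compounds below may be only part of what the source reports. "The series", "measured", "known", "first", "only" and "open" are said of these compounds alone.

Measured in a functional assay on DU-145 cells (Homo sapiens) for antiproliferative activity, read by propidium iodide staining, with a stated time of 96 h; on this read-out lower numbers stand for stronger inhibition and higher numbers for weaker inhibition:
- compound 1 `CC(O)(CSc1ccc(C(F)(F)F)cn1)C(=O)Nc1ccc(S(F)(F)(F)(F)F)cc1`: 30700 nM
- compound 2 `CC(O)(CSc1ccc(S(F)(F)(F)(F)F)cc1)C(=O)Nc1cccc(S(F)(F)(F)(F)F)c1`: 24800 nM
- compound 3 `CC(O)(CSc1ccc(C(F)(F)F)cc1)C(=O)Nc1cccc(S(F)(F)(F)(F)F)c1`: 27200 nM

Compound 3, at 27200 nM, lies within the usual scatter of both compound 2 and compound 1, so these numbers do not rank it against either of them.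

Compound 4 `CC(O)(CSc1ccccc1C(F)(F)F)C(=O)Nc1cccc(S(F)(F)(F)(F)F)c1` has the same atoms as compound 3, joined differently: 2-(trifluoromethyl)phenyl in place of 4-(trifluoromethyl)phenyl on a sulfur. In words, this is 2-(trifluoromethyl)phenyl in place of 4-(trifluoromethyl)phenyl on a sulfur.

Within the data shown here, no measured step makes this kind of change. The closest evidence is a 1.1-fold higher number from compound 2 to compound 3 (0.04 log units; within the scatter), which swaps one group on that same aromatic ring and stays within the scatter. That step shows some tolerance for change on this ring, but it says nothing direct about moving a group, so the uncertainty remains wide. No step beyond the scatter is therefore expected, and no direction can be favoured.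

The expected step is a 1.0-fold lower number from compound 3 to compound 4 (0.00 log units; within the scatter). The estimated value for compound 4 is 27000 nM, with an expected range from 13000 nM to 55000 nM.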

Compound 4, half-maximal inhibitory concentration: 15800 nM
Compound 4: middle estimate off by 1.7-fold (0.23 log units), on the high side; the range from low to high includes it.
By their numbers in this assay, from the lowest: compounds 4, 2, 3 and 1 (each within the scatter of the next).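

Shifting the trifluoromethyl group, rather than replacing it, is a new kind of change for this series. Putting 2-(trifluoromethyl)phenyl in place of 4-(trifluoromethyl)phenyl on the sulfur gives a 1.7-fold lower number from compound 3 to compound 4 (0.24 log units; within the scatter) in this assay, so this single pair does not separate the two placements, and the position of the group cannot be said to matter or not to matter for this read-out. No measurement shown here helps to interpret this step.

Going by these compounds, it remains open whether any change on this ring can move the number beyond the scatter. A clearly different group in the same place, such as an amine, a carboxylic acid or a longer chain, would test that more sharply than the close relatives shown so far.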